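The source may hold more compounds than are shown below. What is called first, only, known or untested is meant among the compounds shown, and "the series" means these compounds.

Going by the values given here, compound 2 `CC(=O)NCC1CCCN(S(=O)(=O)c2ccc(F)cc2)C1` holds the higher of the two numbers so far in a functional assay on the whole organism with Mus musculus as the target, with a stated time of 30 min (a higher number here means that more compound is needed for the effect, a lower number that less compound is needed), where compound 2 gives 10 mg/kg. Compound 1 `CC(=O)NC1CCCN(S(=O)(=O)c2ccc(F)cc2)C1` gives 1 mg/kg, and the step of a 10-fold higher number from compound 1 to compound 2 (1.00 log units; beyond the scatter) separates the pair. Compound 3 `CCC(=O)NCC1CCCN(S(=O)(=O)c2ccc(F)cc2)C1` differs from compound 2 by methyl in place of hydrogen on a saturated chain carbon bound to a carbonyl carbon. Among the compounds with values here, the only measured step, a 10-fold higher number from compound 1 to compound 2 (1.00 log units; beyond the scatter), concerns a different part of the structure and offers no direct guide to this change. With nothing to point either way, the expected step is no change at the digits printed from compound 2 to compound 3 (within the scatter), within the scatter. Compound 3 is therefore estimated at 10 mg/kg, with a likely range from 3 mg/kg to 30 mg/kg.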

Compound 3, minimum effective dose: 10 mg/kg
Estimate against measurement, compound 3: no gap at the digits printed, and the stated range covers the measured number.
By their numbers in this assay, from the lowest: compound 1; then compounds 2 and 3 (each within the scatter of the next).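

In this assay, methyl in place of hydrogen on a saturated chain carbon bound to a carbonyl carbon, which turns acetyl into propanoyl, gives no change at the digits printed from compound 2 to compound 3 (within the scatter) and so shows that this position takes the added methyl without a shift beyond the scatter. The propanoyl group also does not bring back the lower number of compound 1, with a 10-fold higher number from compound 1 to compound 3 (1.00 log units; beyond the scatter) on the same scale as the earlier step. On these data alone, whether a longer chain such as butanoyl or an amine at this position would behave alike remains open. No measurement here explains these results.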